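Hydroxymethyl for sec-butyl: estimate for compound 4

The compounds below may be only part of what the source reports. "The series", "measured", "known", "first", "only" and "open" are said of these compounds alone.

Three compounds have been run in a functional assay on the whole organism (Tail, strain ICR) with Mus musculus as the target, in the tail flick test, with a stated time of 150 min, at a dose of 25 umol/kg by the oral route; on this read-out lower numbers stand for a weaker effect and higher numbers for a stronger effect at the one dose given. Compound 1 `CC[C@H](C)[C@H](NC(=O)CN(c1nc(Cl)nc2[nH]cnc12)C1CC1)C(=O)OCc1ccccc1` gives 6.9% in this assay, the second highest of the three numbers. Compound 3 `CC[C@H](C)[C@H](NC(=O)CN(c1nc(Cl)nc2[nH]cnc12)C1CC1)C(=O)O`, its free acid, gives 6.71%, and the step of a number 0.2 percentage points lower from compound 1 to compound 3 (within the scatter) shows that exchanging the benzyl ester for the acid leaves the read-out unchanged within the scatter. Compound 2 `NC(=O)C[C@H](NC(=O)CN(c1ncnc2c1ncn2C1CCCCO1)C1CC1)C(=O)OCc1ccccc1`, which carries a different core and a different side chain, gives 21.7%, higher than compound 1 beyond the scatter; as two things change at once, nothing can be drawn from it for a single substitution.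

Compound 4 `O=C(CN(c1nc(Cl)nc2[nH]cnc12)C1CC1)N[C@@H](CO)C(=O)OCc1ccccc1` differs from compound 1 in one place: hydroxymethyl in place of sec-butyl on a saturated chain carbon bound to an amide-type nitrogen and a carbonyl carbon. Going by the values given here, no measured step touches this position, so the only guide is that the single change recorded so far (from compound 1 to compound 3) stayed within the scatter, and that one polar-side-chain compound, compound 2, sits higher but differs in its core as well. Compound 4 is therefore expected to remain near compound 1, with the step of a number 3.1 percentage points higher from compound 1 to compound 4 (within the scatter) estimated as within or at the edge of the scatter and the direction uncertain. The estimate for compound 4 in this assay is 10%, with a range from 0% to 25%.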

Compound 4, a percentage reported as activity, at one dose (the size of the read-out at that dose, not a potency): 27.9%
Estimate against measurement, compound 4: 17.9 percentage points below, outside the stated range (above it).
By their numbers in this assay, from the lowest: compounds 3 and 1 (each within the scatter of the next); then compounds 2 and 4 (each within the scatter of the next).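

In this assay, going by these compounds alone, the saturated chain carbon bound to an amide-type nitrogen and a carbonyl carbon is the first place where a single change moves the read-out beyond the scatter: hydroxymethyl in place of sec-butyl gives a number 21 percentage points higher from compound 1 to compound 4 (beyond the scatter) on the shared core. Within the data shown here, the only earlier single change, hydrogen in place of benzyl on an oxygen next to a carbonyl group, gave a number 0.2 percentage points lower from compound 1 to compound 3 (within the scatter) and so left open whether any one-place change on this core would register at this dose. No measurement on hand accounts for the gain seen with hydroxymethyl.

Hydroxymethyl differs from sec-butyl both in carrying a hydroxyl oxygen and in being the shorter chain, and the compounds shown do not separate these two; a plain methyl or ethyl group at this carbon, set against a longer chain such as hydroxyethyl, would do so. Also open, as far as these compounds go, is whether the free carboxylic acid of compound 4 stays level with its benzyl ester, as the acid of compound 1 does.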